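Swapping a sulfamoyl group for chlorine on the aniline ring

The source may hold more compounds than are shown below. What is called first, only, known or untested is meant among the compounds shown, and "the series" means these compounds.

Measured so far:
compound 1, `CC1=NN(C(=O)c2cc3ccccc3oc2=O)C(=O)C1CNc1cccc(S(N)(=O)=O)c1`, 67.8%
compound 2, `CC1=NN(C(=O)c2cc3ccccc3oc2=O)C(=O)C1CNc1ccc(S(N)(=O)=O)cc1`, 68.9%
compound 3, `CC1=NN(C(=O)c2cc3ccccc3oc2=O)C(=O)C1CNc1c(O)cc(S(=O)(=O)O)c2ccccc12`, 21.6%

All three share one core and differ only in the aromatic group attached to an amine nitrogen. In a functional assay on the whole organism for inhibition, with Rattus norvegicus as the target, read by paw edema, with stated times of 1 h and 4 h, at a dose of 0.03 mg/kg by the oral route (a higher number here means more inhibition at the dose given (going by the name of the read-out), a lower number less inhibition), compound 1 gives 67.8%, the second highest of the three numbers. Compound 2 sits closest, with a number 1.1 percentage points higher from compound 1 to compound 2 (within the scatter), so the two sulfamoylphenyl compounds cannot be told apart. Compound 3, carrying a larger, acidic naphthalene-based group, stands far lower at 21.6%.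

Compound 4 is `CC1=NN(C(=O)c2cc3ccccc3oc2=O)C(=O)C1CNc1ccc(Cl)cc1`. Compared with compound 1 the change is 4-chlorophenyl in place of 3-sulfamoylphenyl on an amine nitrogen

For the measured compounds named here, no measured step matches this change. Going by the values given here, the only step that does, from compound 1 to compound 2, moves the sulfamoyl group around the ring and shows nothing beyond the scatter, while compound 3 shows that a very different aromatic group can cut the read-out sharply. Removing the sulfamoyl group entirely is a bigger change than the first step and a smaller one than the second, so a moderate drop in this assay is expected, with wide uncertainty: a number 12.8 percentage points lower from compound 1 to compound 4 (beyond the scatter). Compound 4 is therefore estimated at 55%, expected between 35% and 75%.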

Compound 4, a percentage reported as inhibition, in the whole organism at one dose (the size of the read-out at that dose, not a potency): 43.5%
For compound 4 the middle estimate is 11.5 percentage points above the measured one; measured number inside the range.
By their numbers in this assay, from the lowest: compound 3; then compound 4; then compounds 1 and 2 (each within the scatter of the next).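

Within the sulfamoylphenyl pair, this assay could not separate the two compounds, but here the group on the ring clearly matters: chloro in place of sulfamoyl on an aromatic carbon gives a number 25.4 percentage points lower from compound 2 to compound 4 (beyond the scatter) in this single-change comparison. The wider change, 4-chlorophenyl in place of 3-sulfamoylphenyl on an amine nitrogen, gives a number 24.3 percentage points lower from compound 1 to compound 4 (beyond the scatter), a step of similar size, so at this one dose both sulfamoylphenyl compounds stand apart from the chloro compound in a way that the step between the two sulfamoylphenyl compounds could not reveal. No measurement shown here accounts for this loss of inhibition.

The compounds shown do not tell whether the lower number comes from losing the sulfamoyl group or from gaining the chlorine, a question that a plain phenyl ring on the same amine nitrogen could help to separate. Going by these compounds, it also remains open how other groups in that ring position, such as a carboxylic acid, a methylsulfonyl group or a methoxy group, would compare with sulfamoyl and chloro.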